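The compounds below may be only part of what the source reports. "The series", "measured", "known", "first", "only" and "open" are said of these compounds alone.

Series notes on the shared core of compound 1 `CC(=O)Nc1ccc(NC(=O)c2cc(Cl)ccc2O)c(Cl)c1`, for which an ADME assay on A549 cells (Homo sapiens) for cytotoxicity, read by resazurin assay, with a stated time of 48 h (on this read-out higher numbers stand for lower toxicity in this test and lower numbers for higher toxicity in this test), reports "not determined" (no result reported). Compound 2 `CCN(CC)c1ccc(NC(=O)c2cc(Cl)ccc2O)c(Cl)c1` gives 55500 nM in this assay. Among the measured compounds shown here, compound 3 `O=C(Nc1ccc(NCc2ccc(Br)cc2)cc1Cl)c1cc(Cl)ccc1O` gives 40900 nM in this assay; the two known numbers differ only by a 1.4-fold lower number from compound 2 to compound 3 (0.13 log units; within the scatter), which is within the scatter, so compound 3 cannot be set apart from compound 2 on these data. Compound 4 `CC(CCO)Nc1ccc(NC(=O)c2cc(Cl)ccc2O)c(Cl)c1` carries 3-hydroxy-1-methylpropyl in place of 4-bromobenzyl on a nitrogen on an aromatic ring. For the measured compounds named here, the only measured step that bears on an exchange at this nitrogen is a 1.4-fold lower number from compound 2 to compound 3 (0.13 log units; within the scatter), and it stayed within the scatter, so no step beyond the scatter is expected here in this assay. The expected step is a 1.2-fold higher number from compound 3 to compound 4 (0.09 log units; within the scatter). Compound 4 is therefore estimated at 50000 nM in this assay, with a range from 20000 nM to 120000 nM.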

Compound 4, half-maximal cytotoxic concentration: 200000 nM
For compound 4 the middle estimate is 4.0-fold (0.60 log units) below the measured one; the measured number lies above the stated range.
By their numbers in this assay, from the lowest: compounds 3 and 2 (each within the scatter of the next); then compound 4.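

The exchange at this nitrogen now moves the number in this assay beyond the scatter (a 4.9-fold higher number from compound 3 to compound 4 (0.69 log units; beyond the scatter)), and the same holds against the diethylamino group (a 3.6-fold higher number from compound 2 to compound 4 (0.56 log units; beyond the scatter)). The substituent here can therefore shift this read-out towards lower toxicity in this test, which the step between compound 2 and compound 3 did not show. Nothing measured here accounts for the shift.

Going by these compounds, it remains open whether the hydroxy group or the branched chain carries the step; a 3-hydroxypropyl or a 1-methylpropyl group would separate the two.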